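Replacing isopropyl with cyclobutyl on the amide nitrogen

The source may report more compounds than this note shows. Statements on the series, on what has been measured and on what is new or still open speak of the compounds shown alone.

Compound 3 `CNC(=O)c1cc(C(=O)NC(C)C)cn(Cc2ccccc2)c1=O` shows the highest number among the three measured compounds in a physicochemical assay for lipophilicity, at pH 7.4 (on this read-out higher numbers stand for higher lipophilicity and lower numbers for lower lipophilicity), giving 3.6. Compound 2 `CNC(=O)c1cc(C(=O)NC2CC2)cn(Cc2ccc(F)cc2)c1=O` gives 3.2, and compound 1 `CNC(=O)c1cc(C(=O)NC2CC2)cn(Cc2ccc(OC)cc2)c1=O` gives 3. Within the data shown here, the only measured single change, a number 0.20 log units higher from compound 1 to compound 2 (within the scatter), concerns the aromatic ring and not the amide nitrogen, so no measured step bears directly on the change ahead. Compound 4 `CNC(=O)c1cc(C(=O)NC2CCC2)cn(Cc2ccccc2)c1=O` differs from compound 3 by cyclobutyl in place of isopropyl on an amide-type nitrogen. The entering group carries one more carbon than the leaving group, and on this read-out such an addition usually pushes the number upward by a step comparable to the measured ones. Compound 4 is therefore expected to come out at 3.9, between 3.5 and 4.3, an estimated step of a number 0.30 log units higher from compound 3 to compound 4 (within the scatter).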

Compound 4, distribution coefficient: 3.8
For compound 4 the middle estimate is 0.10 log units above the measured one; measured number inside the range.
By their numbers in this assay, from the lowest: compounds 1 and 2 (each within the scatter of the next); then compounds 3 and 4 (each within the scatter of the next).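

Among these compounds, this is the first measured single change on the amide-type nitrogen: cyclobutyl in place of isopropyl gives a number 0.20 log units higher from compound 3 to compound 4 (within the scatter) in this assay. At this position, then, the two groups cannot be told apart on this read-out, even though the entering group brings a four-membered ring and one more carbon. Nothing measured here offers an explanation for this result. Going by these compounds, whether a longer chain, an amine or a carboxylic acid at this nitrogen would also stay within the scatter remains open. So does whether the same exchange would give a similar step in compounds carrying fluoro or methoxy on the aromatic ring.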